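This account rests on a few compounds, and the source may have more. Where it says the series, first, only, none or still open, it means among the compounds named here.

Three compounds have been measured in an ADME assay (liver) for metabolic stability, with Liver microsome (Rattus norvegicus) as the target, using microsomes and NADPH, with a stated time of 30 min, tested at 1 uM; a lower number here means slower removal, a higher number faster removal of the compound:

Compound 1 `CC(C)(C)n1cc(-c2cc(C(O)(C(F)(F)F)C(F)(F)F)cnc2N2CCN(S(=O)(=O)c3ccc(N)nc3)CC2)cn1`: 459 mL.min-1.g-1
Compound 2 `Cc1csc(-c2cc(C(O)(C(F)(F)F)C(F)(F)F)cnc2N2CCN(S(=O)(=O)c3ccc(N)nc3)CC2)c1`: 399 mL.min-1.g-1
Compound 3 `Nc1ccc(S(=O)(=O)N2CCN(c3ncc(C(O)(C(F)(F)F)C(F)(F)F)cc3-c3cccc(F)c3)CC2)cn1`: 52 mL.min-1.g-1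

Compound 3 has the lowest number of the three, and its gaps to both others lie beyond the scatter. Compound 4 `Nc1ccc(S(=O)(=O)N2CCN(c3ncc(C(O)(C(F)(F)F)C(F)(F)F)cc3-c3cccnc3)CC2)cn1` keeps the shared core and has pyridin-3-yl in place of 3-fluorophenyl on an aromatic carbon.

All three measured steps exchange the group on that same aromatic carbon. Bringing in 3-fluorophenyl gave an 8.8-fold lower number from compound 1 to compound 3 (0.95 log units; beyond the scatter) and a 7.7-fold lower number from compound 2 to compound 3 (0.88 log units; beyond the scatter), both modest. The exchange between the other two groups gave a 1.2-fold lower number from compound 1 to compound 2 (0.06 log units; within the scatter). None of these steps involves pyridin-3-yl, so the direction is poorly supported by the data. Both groups in the new change are six-membered aromatic rings, so a step smaller than the two modest ones seems likely. The step expected in this assay is a 1.2-fold lower number from compound 3 to compound 4 (0.06 log units; within the scatter), with no clear move beyond the scatter. Compound 4 is estimated at 45 mL.min-1.g-1, with an expected range of 16 mL.min-1.g-1 to 130 mL.min-1.g-1.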

Compound 4, intrinsic clearance in microsomes: 20 mL.min-1.g-1
For compound 4 the middle estimate is 2.3-fold (0.35 log units) above the measured one; measured number inside the range.
By their numbers in this assay, from the lowest: compound 4; then compound 3; then compounds 2 and 1 (each within the scatter of the next).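

In this assay, exchanging 3-fluorophenyl for pyridin-3-yl on this aromatic carbon gave a 2.6-fold lower number from compound 3 to compound 4 (0.41 log units; beyond the scatter), which shows that a swap between two six-membered aromatic rings can still move the number beyond the scatter. Measured against the two other groups at this position, the change gave a 20-fold lower number from compound 2 to compound 4 (1.30 log units; beyond the scatter) and a 23-fold lower number from compound 1 to compound 4 (1.36 log units; beyond the scatter), the first large steps seen here, and compound 4 now has the lowest number of the four. No measurement at hand bears on why this change lowers the number.

The compounds shown leave open whether the location of the ring nitrogen matters, or whether a pyrimidin-5-yl ring or an amine on this carbon would lower the number further. They also leave open whether the step would hold with a carboxylic acid in place of the 2,2,2-trifluoro-1-hydroxy-1-(trifluoromethyl)ethyl group.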